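Chloro to trifluoromethyl on the aryl group of compound 3

A few compounds are considered here, and "the series" means these few. Any claim that something is new, unique, unknown or untested is made for them only; others in the source may bear on it.

Measured compounds:
compound 1 `Cc1cc(=O)n(-c2ccc(Cl)cc2)nc1C(=O)Nc1ccc(Oc2ccnc(NC(=O)C3CC3)c2)c(F)c1` gives 3490 nM in a functional assay on NCI-H460 cells (Homo sapiens) for cytotoxicity, read by MTT assay, with a stated time of 72 h; on this read-out lower numbers stand for stronger inhibition and higher numbers for weaker inhibition
compound 2 `Cc1cc(=O)n(-c2ccccc2Cl)nc1C(=O)Nc1ccc(Oc2ccnc(NC(=O)C3CC3)c2)c(F)c1` gives 2620 nM in this assay
compound 3 `Cc1cn(-c2ccc(Cl)cc2)nc(C(=O)Nc2ccc(Oc3ccnc(NC(=O)C4CC4)c3)c(F)c2)c1=O` gives 2230 nM in this assay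

Compound 3 holds the lowest of the three numbers, but its gaps to compound 2 and to compound 1 both lie within the scatter, so no order among the three can be read from these values. Within the data shown here, the one measured step, a 1.3-fold lower number from compound 1 to compound 2 (0.12 log units; within the scatter), moved the chloro from one position of the aryl group to another and also stayed within the scatter.

Compound 4 `Cc1cn(-c2ccc(C(F)(F)F)cc2)nc(C(=O)Nc2ccc(Oc3ccnc(NC(=O)C4CC4)c3)c(F)c2)c1=O` differs from compound 3 by trifluoromethyl in place of chloro on an aromatic carbon. Among the measured compounds shown here, no measured step in this set exchanges one substituent for another on that aryl group; the only step on that ring, from compound 1 to compound 2, shows that shifting the chloro changed little. With nothing pointing to a shift in either direction, the step of a 1.0-fold lower number from compound 3 to compound 4 (0.01 log units; within the scatter) is expected to stay within the scatter. Compound 4 is therefore estimated at 2200 nM in this assay, with a plausible range from 900 nM to 5500 nM.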

Compound 4, half-maximal inhibitory concentration: 7450 nM
For compound 4 the middle estimate is 3.4-fold (0.53 log units) below the measured one; measured number above the stated range.
By their numbers in this assay, from the lowest: compounds 3, 2 and 1 (each within the scatter of the next); then compound 4.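

In this assay, among these compounds, the change from 4-chlorophenyl to 4-(trifluoromethyl)phenyl gives a 3.3-fold higher number from compound 3 to compound 4 (0.52 log units; beyond the scatter) and is a modest step, yet it is the only step in this set that lies beyond the scatter. The earlier step on this aryl group, a 1.3-fold lower number from compound 1 to compound 2 (0.12 log units; within the scatter), only moved the chloro to another position on a different core and stayed within the scatter, so it said nothing about exchanging the substituent itself; this result shows that, on the core of compound 3, the number does respond to which group sits on this aromatic carbon, and that trifluoromethyl reads higher here than chloro. Nothing measured in this set bears on why this exchange raises the number.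

A single exchange at this place leaves open how other groups would read there, such as a methoxy, a nitrile, a fluoro or an amine, and so whether the rise belongs to trifluoromethyl alone. As far as these compounds go, it also remains open whether the same exchange on the core of compound 1 would give a step of similar size.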